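The source may report more compounds than this note shows. Statements on the series, on what has been measured and on what is new or still open speak of the compounds shown alone.

Measured so far:
compound 1 `CCN1C(=O)CC[C@H]1C(=O)NCc1ccccc1Cl` — 631 nM
compound 2 `CCN1C(=O)CC[C@H]1C(=O)NCc1cccc(C(F)(F)F)c1` — 100 nM

In an assay on isolated protein for inhibition of P2X purinoceptor 7 (Homo sapiens) (on this read-out higher numbers stand for weaker inhibition and lower numbers for stronger inhibition), compound 1 gives 631 nM and stands highest of the two numbers; compound 2 gives 100 nM, the lower of the pair, and the gap between them is beyond the scatter. Compound 3 `CCN1C(=O)CC[C@H]1C(=O)NCc1ccccc1OC` is not yet measured. It differs from compound 1 in one place: methoxy in place of chloro on an aromatic carbon. Among the measured compounds shown here, no measured pair shows this change, so its size is unknown. The step of a 1.3-fold higher number from compound 1 to compound 3 (0.10 log units; within the scatter) is expected to be small, in either direction or none beyond the scatter. In this assay compound 3 is estimated at 800 nM, with a range from 250 nM to 2500 nM.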

Compound 3, half-maximal inhibitory concentration: < 1000 nM
Compound 3: only a limit was reported (the forecaster's own chance of this, stated with the estimate: 10%); the middle value does not contradict the limit.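

Among the compounds shown here, compound 3 carries only a limit in this assay, < 1000 nM, so no step between compound 1 and compound 3 can be read. On these data alone, whether methoxy in place of chloro shifts inhibition beyond the scatter remains open.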